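Dimethylcarbamoyl for hydroxymethyl on a shared benzimidazole-type core

The source may report more compounds than this note shows. Statements on the series, on what has been measured and on what is new or still open speak of the compounds shown alone.

Three compounds built on one shared core have been examined in an ADME assay on HEp-2 cells (Homo sapiens) for cytotoxicity; on this read-out lower numbers stand for higher toxicity in this test and higher numbers for lower toxicity in this test. Compound 2 `CC(C)CCn1c(Cn2c(=O)n(C(C)C)c3ccccc32)nc2cc(CO)ccc21` gives 31600 nM, the highest of the three numbers. Compound 3 `C=C(C)n1c(=O)n(Cc2nc3cc(C(=O)O)ccc3n2CCC(C)C)c2ccccc21` gives 30000 nM, which lies within the usual scatter of the value of compound 2, so nothing separates the two. Compound 1 `CC(C)CCn1c(Cn2c(=O)n(C(C)C)c3ccccc32)nc2c(CN)cccc21` gives 7000 nM, a lower number that lies beyond the scatter of compound 2.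

The step of interest leads from compound 2 to compound 4 `CC(C)CCn1c(Cn2c(=O)n(C(C)C)c3ccccc32)nc2cc(C(=O)N(C)C)ccc21`, which is not yet measured in this assay. The change is dimethylcarbamoyl in place of hydroxymethyl on an aromatic carbon. No step between two measured compounds that differ in a single place has been recorded, so the size of this step cannot be read off a precedent among the three compounds shown.

In the absence of such a precedent, the step from compound 2 to compound 4 in this assay is expected to be small, a 1.1-fold lower number from compound 2 to compound 4 (0.02 log units; within the scatter), with no movement beyond the scatter in either direction. Compound 4 is therefore estimated to give 30000 nM in this assay, with a range from 12000 nM to 80000 nM.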

Compound 4, half-maximal cytotoxic concentration: 25600 nM
The estimate for compound 4 lay 1.2-fold (0.07 log units) above the measured number, within the range that was stated.
By their numbers in this assay, from the lowest: compound 1; then compounds 4, 3 and 2 (each within the scatter of the next).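

In this assay, among the compounds shown here, the exchange of hydroxymethyl for dimethylcarbamoyl gives the first step on the shared core that differs in a single place, a 1.2-fold lower number from compound 2 to compound 4 (0.09 log units; within the scatter), so the read-out does not separate the two compounds. At this aromatic carbon, meta to a fused ring and para to a fused ring, a group of 5 heavy atoms with 0 hydrogen-bond donors thus stands in place of one of 2 heavy atoms with 1 hydrogen-bond donor, with no movement beyond the scatter in this single pair. Nothing measured here offers an explanation for this outcome.

The compounds shown leave open whether other groups at this same aromatic carbon, such as a nitrile, a primary amide or a longer chain such as hydroxyethyl, would also stay within the scatter of compound 2. They also leave open whether dimethylcarbamoyl in place of hydroxymethyl would give a similar step on another aromatic carbon of this ring, or on a core that differs elsewhere.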